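Solubility at the Limit: From Pyridinyl to Spirocyclic Amine

This account rests on a few compounds, and the source may have more. Where it says the series, first, only, none or still open, it means among the compounds named here.

The measured compounds and their values in a physicochemical assay for solubility, read by spectrophotometry, in phosphate buffer, with a stated time of 2 h, at pH 7.4 (a lower number here means a less soluble compound, a higher number a more soluble compound), are:
compound 1, `COc1cccc(CN2C(=O)CN(C(=O)c3cc4cc(OC)ccc4[nH]3)C[C@@H]2CC2CCCCC2)c1`, 21400 nM;
compound 2, `COc1cccc(CN2C(=O)CN(C(=O)c3cc4cc(OC)ccc4[nH]3)C[C@@H]2Cc2ccccn2)c1`, 57900 nM;
compound 3, `COc1ccc2[nH]c(C(=O)N3CC(=O)N(Cc4ccccc4)[C@@H](Cc4ccccn4)C3)cc2c1`, > 100000 nM.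

Compound 3 stands at the top of the measured set. Its value in this assay is a limit and not a number, the one described by the limit of > 100000 nM in this assay, at which 1 of the 3 values shown sits. The two measured steps both point upward: a 2.7-fold higher number from compound 1 to compound 2 (0.43 log units; beyond the scatter) and an at least 1.7-fold higher number from compound 2 to compound 3 (0.23 log units; that floor lies within the scatter), the latter resting only on a floor.

Compound 4, `COc1ccc2[nH]c(C(=O)N3CC(=O)N(Cc4ccccc4)[C@@H](CN4CCC5(CCCC5)CC4)C3)cc2c1`, differs from compound 3 by a group of 10 heavy atoms (9 carbon, 1 nitrogen; one five-membered non-aromatic ring of carbon only, one six-membered non-aromatic ring with 1 hetero atom) in place of a group of 6 heavy atoms (5 carbon, 1 nitrogen; one six-membered aromatic ring with 1 hetero atom), on a saturated chain carbon bound to a saturated ring carbon. For the measured compounds named here, no measured step exchanges a pyridin-2-yl group for a group of this kind, so the only measured bearing is that compound 3 already sits at a limit. The expectation for compound 4 is therefore that this assay again returns a value at or around that limit, with a step from compound 3 estimated as a step that the limit leaves unreadable from compound 3 to compound 4, no direction beyond the scatter. The estimate for compound 4 is 110000 nM, expected to fall between 35000 nM and 300000 nM.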

Compound 4, solubility: 5000 nM
Compound 4: the middle estimate sits 22-fold (1.34 log units) above what was measured; measured number outside the range, below it.
By their numbers in this assay, from the lowest: compound 4; then compound 1; then compound 2. At a limit, above all of these: compound 3.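

At this place, on a saturated chain carbon bound to a saturated ring carbon, the number in this assay can fall sharply, as the new group gives an at least 20-fold lower number from compound 3 to compound 4 (1.30 log units; beyond the scatter), although the two groups carry the same printed counts of hydrogen-bond donors and acceptors and no net charge. For the compounds shown here, the only earlier change at this place, pyridin-2-yl for cyclohexyl, was far smaller, with a 2.7-fold higher number from compound 1 to compound 2 (0.43 log units; beyond the scatter). Compound 3 is held at a limit and not a number, so the new step is only a floor: the limit of > 100000 nM in this assay, at which 1 of the 4 values shown sits.

The compounds shown leave open which part of the entering group goes with the drop, since they do not separate its five-membered carbon ring from its nitrogen-bearing six-membered ring. A plain piperidine or a morpholine at the same place would bear on that.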